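Benzyl for tert-butyl, repeated on a thiophene-bearing core

The source may report more compounds than this note shows. Statements on the series, on what has been measured and on what is new or still open speak of the compounds shown alone.

Three compounds were measured in an assay on membranes from CHO cells for displacement of a labelled ligand from adenosine receptor A1 (Homo sapiens), read by scintillation counting, with a stated time of 60 min, tested at 1 uM; on this read-out lower numbers stand for less inhibition and higher numbers for more inhibition at the one concentration tested (going by the name of the read-out). Compound 1 `CC1=C(C(=O)OC(C)(C)C)C(c2ccoc2)NC(=S)N1` gives 18% and compound 2 `CC1=C(C(=O)OCc2ccccc2)C(c2ccoc2)NC(=S)N1` gives 25%. The change between them is benzyl in place of tert-butyl on an oxygen next to a carbonyl group and it made a number 7 percentage points higher from compound 1 to compound 2 (within the scatter). Compound 3 `CC1=C(C(=O)OC(C)(C)C)C(c2ccsc2)NC(=S)N1` gives 16%; its core differs from the core of compound 1 by thiophen-3-yl in place of furan-3-yl on a saturated ring carbon, a difference of a number 2 percentage points lower from compound 1 to compound 3 (within the scatter). Compound 4 `CC1=C(C(=O)OCc2ccccc2)C(c2ccsc2)NC(=S)N1` has not yet been measured. It carries the same change relative to compound 3, (benzyl in place of tert-butyl on an oxygen next to a carbonyl group), at a place described in identical words. Because a number 7 percentage points higher from compound 1 to compound 2 (within the scatter) stayed within the scatter, a step of similar size is expected for compound 4, a number 6 percentage points higher from compound 3 to compound 4 (within the scatter). Compound 4 is therefore estimated to give 22% in this assay, with a likely range from 8% to 36%.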

Compound 4, a percentage reported as inhibition, at one concentration (the size of the read-out at that concentration, not a potency): 3%
Estimate against measurement, compound 4: 19 percentage points above, and the stated range ends above it.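

In this assay, benzyl in place of tert-butyl gave a number 13 percentage points lower from compound 3 to compound 4 (beyond the scatter) and so did not repeat its earlier result: the same change on two cores in this assay, a number 7 percentage points higher (within the scatter) from compound 1 to compound 2 and a number 13 percentage points lower (beyond the scatter) from compound 3 to compound 4, 20 percentage points apart, beyond the scatter of two such steps.
Thiophen-3-yl in place of furan-3-yl likewise gave a number 22 percentage points lower from compound 2 to compound 4 (beyond the scatter) on the benzyl side, which does not match the step on the tert-butyl side: the same change on two cores in this assay, a number 2 percentage points lower (within the scatter) from compound 1 to compound 3 and a number 22 percentage points lower (beyond the scatter) from compound 2 to compound 4, 20 percentage points apart, beyond the scatter of two such steps.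
This shows that neither change carried over unaltered between these cores, but with a single pair for each comparison it does not explain the mismatch or show how any other core would behave.

The compounds shown leave open whether an ethyl ester or a longer chain on that oxygen would follow the benzyl or the tert-butyl result. They also leave open how an amide in place of the ester would behave.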